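The source may report more compounds than this note shows. Statements on the series, on what has been measured and on what is new or still open speak of the compounds shown alone.

Of the compounds shown here, three sharing one core have been measured in a functional assay on HL-60 cells (Homo sapiens) for inhibition, read by MTT assay, with a stated time of 48 h, tested at 10 uM; on this read-out higher numbers stand for more inhibition of growth at the one concentration tested and lower numbers for less inhibition of growth. Compound 1 `Cc1oc2c([C@H]3CCN(C)C[C@H]3O)c(O)cc(O)c2c(=O)c1C(O)c1c(Cl)cccc1Cl` gives 14% in this assay. Compound 2 `Cc1oc2c([C@H]3CCN(C)C[C@H]3O)c(O)cc(O)c2c(=O)c1C(O)c1c(F)cccc1Cl` gives 49%. Compound 3 `CN1CC[C@H](c2c(O)cc(O)c3c(=O)cc(/C=C/c4ccccc4F)oc23)[C@H](O)C1` gives 62%, the highest of the three numbers, and its lead over compound 2 and over compound 1 lies beyond the usual scatter of this assay. The cores of compound 2 and compound 3 are not the same, but that difference is not broken down here.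

Compound 1 and compound 2 differ in one place: chloro in place of fluoro on an aromatic carbon. This single change made a number 35 percentage points lower from compound 2 to compound 1 (beyond the scatter), a large step.

Compound 4 `CN1CC[C@H](c2c(O)cc(O)c3c(=O)cc(/C=C/c4ccccc4Cl)oc23)[C@H](O)C1` has not yet been measured in this assay. It differs from compound 3 by chloro in place of fluoro on an aromatic carbon. Among the measured compounds shown here, this is the same kind of change as the one from compound 2 to compound 1, but not the same change: in compound 2 the place is also meta to a chloro group, while in compound 3 no such group sits nearby, and the two cores differ as well.

For the measured compounds named here, only one measured example of this change exists, so the expectation rests on a single step in a different setting. Compound 4 is expected to show a step of a number 22 percentage points lower from compound 3 to compound 4 (beyond the scatter), a drop in the same direction because a number 35 percentage points lower from compound 2 to compound 1 (beyond the scatter). Compound 4 is therefore estimated at 40%, most likely between 20% and 60%.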

Compound 4, percent growth inhibition at one concentration: 61%
The estimate for compound 4 lay 21 percentage points below the measured number, and the stated range ends below it.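

In this assay, the change from 2-fluorophenyl to 2-chlorophenyl gave a number 1 percentage points lower from compound 3 to compound 4 (within the scatter), so on this core compound 3 and compound 4 cannot be told apart. Swapping fluoro for chloro therefore does not carry a fixed size of effect from one core to the other in this series, as the two steps side by side show: the same change on two cores in this assay, a number 35 percentage points lower (beyond the scatter) from compound 2 to compound 1 and a number 1 percentage points lower (within the scatter) from compound 3 to compound 4, 34 percentage points apart, beyond the scatter of two such steps What this does not show is which difference between the two settings matters, since the cores differ and compound 1 and compound 2 also carry a further chloro group on the ring, and one pair per core cannot separate these, nor say how a third core would behave.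

The compounds shown hold only fluoro or chloro at this place on the ring, so it remains open how a methyl group, a methoxy group or a nitrile would read there in this assay on the core of compound 3. Also open, as far as these compounds go, is how a plain phenyl ring without any such group would compare with compound 3 and compound 4, which would show whether a group at this place matters at all on this core.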